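The source may report more compounds than this note shows. Statements on the series, on what has been measured and on what is new or still open speak of the compounds shown alone.

Measured so far:
compound 1 `CNC1=CC(=O)c2c(cnc(C)c2C)C1=O` — in a functional assay on cells (Homo sapiens) for cytotoxicity, read by propidium iodide staining, with a stated time of 4 days (on this read-out higher numbers stand for weaker inhibition and lower numbers for stronger inhibition), compound 1 gives 34900 nM
compound 2 `CNC1=CC(=O)c2cc(C)ncc2C1=O` — in this assay compound 2 gives 6600 nM

For the measured compounds named here, compound 2 holds the lowest of the two numbers in this assay; its only neighbour is compound 1, and the single measured step, a 5.3-fold lower number from compound 1 to compound 2 (0.72 log units; beyond the scatter), separates them by more than the scatter. That step concerns a hydrogen in place of methyl on an aromatic carbon.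

Compound 3 `Cc1cc2c(cn1)C(=O)C(NCl)=CC2=O` differs from compound 2 in one place: chloro in place of methyl on an amine nitrogen. Going by the values given here, the change sits on the amine nitrogen, not on the ring, so the one measured step does not bear on it directly; nothing so far shows how a change at this nitrogen moves the number in this assay. Among the compounds with values here, with no anchoring step, the working expectation is a step from compound 2 to compound 3 that is not beyond the scatter, given a wide range to reflect the lack of precedent. The estimated step is a 1.1-fold lower number from compound 2 to compound 3 (0.04 log units; within the scatter). Compound 3 is therefore expected at 6000 nM, with a range of 1500 nM to 25000 nM.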

Compound 3, half-maximal inhibitory concentration: 13900 nM
The estimate for compound 3 lay 2.3-fold (0.36 log units) below the measured number; the range from low to high includes it.
By their numbers in this assay, from the lowest: compound 2; then compound 3; then compound 1.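

At the amine nitrogen the series now has its first measured change: chloro in place of methyl gives a 2.1-fold higher number from compound 2 to compound 3 (0.32 log units; beyond the scatter) in this assay and shows that the number responds to the group on this nitrogen. Of the two groups compared here on this nitrogen, methyl goes with the lower number, though the step is modest and the comparison rests on a single pair of compounds. The data offer no measured basis for explaining this shift.

Still open, as far as these compounds go, is how the number behaves across a wider set of groups on this nitrogen, such as an unsubstituted amine, an ethyl group, a longer chain or an acetyl amide, and whether any of them would fall below compound 2 in this assay and so extend the trend beyond this one pair. Also open, from the compounds shown here alone, is whether chloro in place of methyl on the amine nitrogen would give a step of similar size and direction on the core of compound 1, which carries one more methyl on an aromatic carbon.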